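The source may hold more compounds than are shown below. What is called first, only, known or untested is meant among the compounds shown, and "the series" means these compounds.

Of the compounds shown here, three that share one core have been measured, and a fourth has not. Compound 1 `N#Cc1cccc(COc2c(-c3ccccc3)oc3cc(O)cc(O)c3c2=O)c1` gives 21000 nM in an ADME assay on Huh-5-2 cells (Homo sapiens) for cytotoxicity, read by WST assay, with a stated time of 3 days; a higher number here means that more compound is tolerated, a lower number that less compound is tolerated. Compound 2 `O=c1c(OCc2cccc([N+](=O)[O-])c2)c(-c2ccccc2)oc2cc(O)cc(O)c12` carries nitro in place of cyano on an aromatic carbon, and in this assay compound 2 gives 31000 nM, a step of a 1.5-fold higher number from compound 1 to compound 2 (0.17 log units; within the scatter). Compound 3 `N#Cc1ccc(COc2c(-c3ccccc3)oc3cc(O)cc(O)c3c2=O)cc1` differs from compound 1 by 4-cyanophenyl in place of 3-cyanophenyl on a saturated chain carbon bound to an oxygen on an aromatic ring, and compound 3 gives 48000 nM; the steps are a 2.3-fold higher number from compound 1 to compound 3 (0.36 log units; beyond the scatter) and a 1.5-fold higher number from compound 2 to compound 3 (0.19 log units; within the scatter). Compound 4 `O=c1c(OCc2ccc([N+](=O)[O-])cc2)c(-c2ccccc2)oc2cc(O)cc(O)c12` is still to be measured. It differs from compound 3 by nitro in place of cyano on an aromatic carbon. For the measured compounds named here, this is the same kind of change as the one from compound 1 to compound 2, though not the same change: in compound 1 the cyano sits meta to a large group, whereas in compound 3 it sits para to a large group. Because the earlier step of a 1.5-fold higher number from compound 1 to compound 2 (0.17 log units; within the scatter) stayed within the scatter, the step from compound 3 to compound 4 is expected to be of similar size, a 1.3-fold higher number from compound 3 to compound 4 (0.10 log units; within the scatter). Compound 4 is therefore estimated to give about 60000 nM, most likely between 30000 nM and 120000 nM.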

Compound 4, half-maximal cytotoxic concentration: 40000 nM
The estimate for compound 4 lay 1.5-fold (0.18 log units) above the measured number; the measured number falls inside the stated range.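

In this assay, putting nitro in place of cyano gives steps on the two cores that do not differ beyond what repeated measurements would scatter: the same change on two cores in this assay, a 1.5-fold higher number (0.17 log units; within the scatter) from compound 1 to compound 2 and a 1.2-fold lower number (0.08 log units; within the scatter) from compound 3 to compound 4, 1.8-fold (0.25 log units) apart, within the scatter of two such steps The new step is a 1.2-fold lower number from compound 3 to compound 4 (0.08 log units; within the scatter), and the other two steps that reach compound 4 are also small, at a 1.3-fold higher number from compound 2 to compound 4 (0.11 log units; within the scatter) and a 1.9-fold higher number from compound 1 to compound 4 (0.28 log units; within the scatter). For the compounds shown here, this shows that, for the 3-substituted and 4-substituted benzyl groups here, the swap carried over from one core to the other without a step that can be told from scatter, but it rests on only two pairs, the opposite directions of the two steps carry no meaning, and it does not show that the swap would behave the same way on any other core.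

From the compounds shown here alone, whether an amine or a carboxylic acid in place of the cyano or nitro group would give a step beyond the scatter remains open. The same holds for a longer chain carrying the aromatic ring.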